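The source may report more compounds than this note shows. Statements on the series, on what has been measured and on what is new or still open speak of the compounds shown alone.

Values in a functional assay on HeLa cells (Homo sapiens) for inhibition, read by MTT assay, with a stated time of 72 h; a lower number here means a stronger inhibitor, a higher number a weaker inhibitor:
- compound 1 `COc1cccc(/C=C/C(=O)Nc2cc(OC)c(OC)c(OC)c2)c1`: 16500 nM
- compound 2 `C=C(Br)C(=O)Nc1cccc(/C=C/C(=O)Nc2ccc(OC(F)(F)F)cc2)c1`: 29000 nM
- compound 3 `COc1cc(NC(=O)/C=C/c2cccc(N)c2)cc(OC)c1OC`: not yet measured

Among the measured compounds shown here, only two numbers are available so far. Compound 1 at 16500 nM and compound 2 at 29000 nM lie within the scatter of each other, so neither can be ranked over the other. Compound 3 keeps the core of compound 1 and carries amino in place of methoxy on an aromatic carbon, meta to a large group, that is, 3-methoxyphenyl to 3-aminophenyl: amino in place of methoxy on an aromatic carbon. For the measured compounds named here, no measured pair isolates this change, so the data give no direct guide to its size or direction in this assay. No step beyond the scatter is expected. The expected step of a 1.1-fold lower number from compound 1 to compound 3 (0.04 log units; within the scatter) is correspondingly small. For compound 3 the estimated value is 15000 nM, with an expected range of 5000 nM to 45000 nM.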

Compound 3, half-maximal inhibitory concentration: 53100 nM
Compound 3: the middle estimate sits 3.5-fold (0.55 log units) below what was measured; measured number outside the range, above it.
By their numbers in this assay, from the lowest: compounds 1, 2 and 3 (each within the scatter of the next, the first and the last beyond it).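

In this assay, among the compounds shown here, amino in place of methoxy on an aromatic carbon, meta to a large group, gives a 3.2-fold higher number from compound 1 to compound 3 (0.51 log units; beyond the scatter) and so provides the first single-place comparison. The step lies beyond the scatter, which shows that this position is not indifferent to the change: going from 3-methoxyphenyl to 3-aminophenyl moves the number in the direction of a weaker inhibitor, by a modest amount. No evidence on hand bears on the reason for this step.

Still open, from the compounds shown here alone, is how other groups at this position would read, for example hydroxy, dimethylamino or acetamido, and whether any of them would match methoxy. Also open, going by these compounds, is whether the same step would appear with a different amide partner, such as the trifluoromethoxy-bearing aryl group of compound 2.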